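This account rests on a few compounds, and the source may have more. Where it says the series, first, only, none or still open, it means among the compounds named here.

Compound 2 `CC(=O)NC[C@H]1CN(c2ccc(OC[C@@H]3CN(c4ccccc4)C(=O)O3)c(F)c2)C(=O)O1` stands second highest of the three numbers in a physicochemical assay for lipophilicity, read by HPLC (a higher number here means a more lipophilic compound, a lower number a more polar compound), where compound 2 gives 1.78. The nearest number is that of compound 3 `CC(=O)NC[C@H]1CN(c2ccc(OC[C@H]3CN(c4ccccc4)C(=O)O3)c(F)c2)C(=O)O1`, which in this assay gives 1.86; the furthest is that of compound 1 `CC(=O)NC[C@H]1CN(c2ccc(OC[C@H](O)CNc3ccc(C#N)cc3)c(F)c2)C(=O)O1`, which gives 1.29. Among the measured compounds shown here, the one step between two compounds differing in a single place, a number 0.08 log units higher from compound 2 to compound 3 (within the scatter), lies within the scatter, which fits (the fact that compounds 2 and 3 differ only in the configuration as drawn).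

Compound 4 `COc1ccc(N2C[C@@H](COc3ccc(N4C[C@H](CNC(C)=O)OC4=O)cc3F)OC2=O)cc1` differs from compound 2 by methoxy in place of hydrogen on an aromatic carbon. For the measured compounds named here, none of the measured steps makes this change: the step from compound 2 to compound 3 concerns configuration alone and does not speak to adding a methoxy group, and compound 1 differs from compound 2 in several places at once. The expectation for compound 4 therefore rests on the value of compound 2 rather than on a measured step, and the step of a number 0.02 log units higher from compound 2 to compound 4 (within the scatter) is expected to stay within the scatter. Compound 4 is expected to give about 1.8 in this assay, within a range from 1.5 to 2.1.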

Compound 4, partition coefficient: 1.91
The estimate for compound 4 lay 0.11 log units below the measured number, within the range that was stated.
By their numbers in this assay, from the lowest: compound 1; then compounds 2, 3 and 4 (each within the scatter of the next).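

In this assay the change from phenyl to 4-methoxyphenyl, with methoxy on an aromatic carbon para to a large group, gives a number 0.13 log units higher from compound 2 to compound 4 (within the scatter) and is the first substitution on this ring among the compounds shown. At this position, then, a group of 2 heavy atoms can take the place of hydrogen while the reading stays within the scatter, which the step in configuration alone could not show. No observation at hand bears on this methoxy change.

From the compounds shown here alone, whether the reading also holds for other groups on this aromatic carbon, such as an amine, a carboxylic acid or a longer alkoxy chain, stays open. Also open, going by these compounds, is how methoxy would read on another carbon of this ring, or with the configuration of compound 3.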